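This account rests on a few compounds, and the source may have more. Where it says the series, first, only, none or still open, it means among the compounds named here.

Among the compounds measured so far, compound 3 `Nc1cc(S(=O)(=O)c2ccccc2Cl)c([N+](=O)[O-])c2cccnc12` stands lowest: in an assay for binding affinity to Neuropeptide Y receptor type 1 (Homo sapiens), read by radioligand binding (a lower number here means a stronger inhibitor, a higher number a weaker inhibitor), compound 3 gives 93 nM. The nearest value comes from compound 1 `Nc1cc(S(=O)(=O)c2ccccc2)c([N+](=O)[O-])c2cccnc12`, which in this assay gives 297 nM. That difference is a 3.2-fold lower number from compound 1 to compound 3 (0.50 log units; beyond the scatter), from a single chloro added on an aromatic carbon. Compound 2 `CS(=O)(=O)c1cc(N)c2ncccc2c1[N+](=O)[O-]` reaches only the limit of this assay, > 10000 nM. The steps of an at least 33-fold higher number from compound 1 to compound 2 (1.52 log units; beyond the scatter) and an at least 100-fold lower number from compound 2 to compound 3 (2.03 log units; beyond the scatter) are both large, but both exchange a whole aryl group for a methyl, not one halogen for another. Compound 4 `Nc1cc(S(=O)(=O)c2ccccc2Br)c([N+](=O)[O-])c2cccnc12` differs from compound 3 by bromo in place of chloro on an aromatic carbon. For the measured compounds named here, no measured step swaps one halogen for another, so only a small change, if any beyond the scatter, is expected: a 1.2-fold lower number from compound 3 to compound 4 (0.07 log units; within the scatter). Compound 4 is therefore estimated at 80 nM, within 30 nM to 250 nM.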

Compound 4, inhibition constant: 234 nM
Beside the measured number, compound 4's estimate is 2.9-fold (0.47 log units) below it, within the range that was stated.
By their numbers in this assay, from the lowest: compound 3; then compounds 4 and 1 (each within the scatter of the next). At a limit, above all of these: compound 2.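

Bromo in place of chloro gives a 2.5-fold higher number from compound 3 to compound 4 (0.40 log units; beyond the scatter), so at this place on the ring the two halogens are not interchangeable. Bromo in place of hydrogen gives a 1.3-fold lower number from compound 1 to compound 4 (0.10 log units; within the scatter), which does not repeat the step seen with chloro. The 2-bromophenyl group still gives an at least 42-fold lower number from compound 2 to compound 4 (1.63 log units; beyond the scatter), a step read against a limit and not a number: the limit of > 10000 nM in this assay, at which 1 of the 4 values shown sits.

From the compounds shown here alone, whether fluoro or methoxy at this place would match chloro stays open. So does the effect of a longer chain on the sulfonyl sulfur.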